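The compounds below may be only part of what the source reports. "The series", "measured", "known", "first", "only" and "open" are said of these compounds alone.

Compound 1 `O=c1[nH]/c(=C\c2c[nH]cn2)c(=O)[nH]/c1=C\c1cccc(Oc2ccc(F)cc2)c1`: 479 nM
Compound 2 `O=c1[nH]/c(=C\c2ccc(Cl)o2)c(=O)[nH]/c1=C\c1cccc(Oc2ccc(F)cc2)c1`: 180 nM

Both compounds were tested in a functional assay on NCI-H460 cells (Homo sapiens) for cytotoxicity, read by MTT assay, with a stated time of 72 h; on this read-out higher numbers stand for weaker inhibition and lower numbers for stronger inhibition. Of the two, compound 2 has the lower number at 180 nM, so it is the stronger inhibitor here. Compound 3 `CC(C)(C)S(=O)(=O)OCc1ccc(/C=c2\[nH]c(=O)/c(=C/c3cccc(Oc4ccc(F)cc4)c3)[nH]c2=O)o1` differs from compound 2 in one place, with (((tert-butyl)sulfonyl)oxy)methyl in place of chloro on an aromatic carbon. Among the measured compounds shown here, only one measured step offers any guide, a 2.7-fold lower number from compound 1 to compound 2 (0.43 log units; beyond the scatter), a modest change beyond the scatter. For the measured compounds named here, that step replaced a whole ring group, so it does not test the new group directly, and no measured compound carries it. Going by these compounds, with so little evidence, no step beyond the scatter is expected in this assay, and the direction stays open. The expected change is a 1.4-fold higher number from compound 2 to compound 3 (0.14 log units; within the scatter). Compound 3 is estimated at 250 nM, with an expected range of 70 nM to 900 nM.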

Compound 3, half-maximal inhibitory concentration: 378 nM
The estimate for compound 3 lay 1.5-fold (0.18 log units) below the measured number, and the stated range covers the measured number.
By their numbers in this assay, from the lowest: compound 2; then compounds 3 and 1 (each within the scatter of the next).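

Compound 2 and compound 3 differ only in the group on the aromatic carbon next to the ring oxygen, so this pair tests that position directly, whereas the earlier step exchanged a whole ring group. In this assay, replacing chloro with (((tert-butyl)sulfonyl)oxy)methyl gives a 2.1-fold higher number from compound 2 to compound 3 (0.32 log units; beyond the scatter), a modest loss even though a single heavy atom gives way to nine, including three hydrogen-bond acceptors. So this position accepts a much larger group while the compound keeps much of its cytotoxicity, but nothing measured here explains why the number rises.

The compounds shown leave open whether the size of the new group or its sulfonyl ester accounts for the step. A plain methyl or a hydroxymethyl at this position could help separate those two possibilities.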